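The compounds below may be only part of what the source reports. "The series", "measured", "known", "first", "only" and "open" are said of these compounds alone.

Measured compounds in an ADME assay on the whole organism (plasma) for pharmacokinetics, with Rattus norvegicus as the target, with a stated time of 6 h, at a dose of 10 mg/kg by the oral route; on this read-out lower numbers stand for lower exposure and higher numbers for higher exposure at the dose given:
compound 1, `Nc1nc(Cl)c(-c2nc3ccccc3s2)c(N[C@@H]2C[C@H](CO)[C@@H](O)[C@H]2O)n1`, gives 32.6 ng.h/mL
compound 2, `Cc1nc(NCC2CC2)nc(N[C@@H]2C[C@H](CO)[C@@H](O)[C@H]2O)c1-c1nc2ccccc2s1`, gives 1410 ng.h/mL
compound 3, `Cc1nc(NCCOC(C)C)nc(N[C@@H]2C[C@H](CO)[C@@H](O)[C@H]2O)c1-c1nc2ccccc2s1`, gives 426 ng.h/mL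

Among these three, compound 3 holds the second highest number. Its nearest neighbour is compound 2, and the step of a 3.3-fold lower number from compound 2 to compound 3 (0.52 log units; beyond the scatter) separates them; compound 1 sits far below both, and the gap between compound 3 and compound 1 is well beyond the scatter. Compound 1 also differs from the others in more than one place, so it offers no single-point comparison.

The next compound, compound 4, `Cc1nc(NCc2ccncc2)nc(N[C@@H]2C[C@H](CO)[C@@H](O)[C@H]2O)c1-c1nc2ccccc2s1`, differs from compound 3 in one place: pyridin-4-yl in place of isopropoxymethyl on a saturated chain carbon bound to a nitrogen on an aromatic ring. Going by the values given here, the only measured step at this same place is a 3.3-fold lower number from compound 2 to compound 3 (0.52 log units; beyond the scatter), which is modest in size. That step shows that exchanging the group on the saturated chain carbon bound to the ring nitrogen can move exposure by a few multiples, but neither of the two measured groups is an aromatic ring, so the direction for pyridin-4-yl is not determined by the data.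

Given this, compound 4 is expected to stay near compound 3, with a slight lean downward, a 1.4-fold lower number from compound 3 to compound 4 (0.15 log units; within the scatter). Compound 4 is estimated at 300 ng.h/mL, with a range from 80 ng.h/mL to 1200 ng.h/mL.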

Compound 4, area under the concentration-time curve: 47.9 ng.h/mL
For compound 4 the middle estimate is 6.3-fold (0.80 log units) above the measured one; the whole stated range lies above it.
By their numbers in this assay, from the lowest: compounds 1 and 4 (each within the scatter of the next); then compound 3; then compound 2.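

In this assay, the place on a saturated chain carbon bound to a nitrogen on an aromatic ring turns out to tolerate less than the one earlier step could show: pyridin-4-yl, the only six-membered aromatic ring at this place among the compounds shown, gives an 8.9-fold lower number from compound 3 to compound 4 (0.95 log units; beyond the scatter), and measured against cyclopropyl it gives a 29-fold lower number from compound 2 to compound 4 (1.47 log units; beyond the scatter). Both steps lie beyond the scatter, and the second is the only one at this place that counts as large, so the three groups now fall in a clear order, with cyclopropyl highest, isopropoxymethyl in the middle and pyridin-4-yl lowest. Going by these compounds alone, nothing available explains why the aromatic ring lowers the number so far, and no cause can be assigned to this change.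

The compounds shown leave open whether the fall belongs to the aromatic ring as such or to its ring nitrogen, a question that phenyl at the same place would address, while pyridin-3-yl or pyridin-2-yl would show whether the location of that nitrogen matters. They also leave open whether a small saturated group such as cyclobutyl or a plain ethyl would hold the number near that of compound 2 1410 ng.h/mL.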